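Pyrrolidine in Place of Benzylamine on Compound 1

The compounds below may be only part of what the source reports. "The series", "measured", "known", "first", "only" and "open" are said of these compounds alone.

The shared core is carried by compound 1 `O=C1C=C(NCc2ccccc2)C(=O)c2c1nc1n2[C@H]2OC[C@@H](O)[C@H]2OC1`, compound 2 `Cc1ccc(NC2=CC(=O)c3c(nc4n3[C@H]3OC[C@@H](O)[C@H]3OC4)C2=O)cc1C`, compound 3 `CCCN(CCC)C1=CC(=O)c2c(nc3n2[C@H]2OC[C@@H](O)[C@H]2OC3)C1=O` and the still unmeasured compound 4 `O=C1C=C(N2CCCC2)C(=O)c2c1nc1n2[C@H]2OC[C@@H](O)[C@H]2OC1`. In a functional assay on HeLa cells (Homo sapiens) for inhibition, read by sulforhodamine B assay (a higher number here means a weaker inhibitor, a lower number a stronger inhibitor), compound 1 reaches only a limit of the assay, > 8000 nM, so no number stands for it; this is the point described by the limit of > 8000 nM in this assay, at which 1 of the 3 values shown sits. Compound 2 gives 4320 nM in this assay. For compound 3 this assay again reports only a limit, > 16000 nM, the point described by the limit of > 16000 nM in this assay, at which 1 of the 3 values shown sits. Among the measured compounds shown here, the one measured step, an at least 3.7-fold higher number from compound 2 to compound 3 (0.56 log units; beyond the scatter), exchanges an arylamino group for a dialkylamino group and weakens inhibition.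

Compound 4 arises from compound 1 by the change (pyrrolidin-1-yl in place of benzylamino on a double-bonded ring carbon). This change resembles the exchange behind an at least 3.7-fold higher number from compound 2 to compound 3 (0.56 log units; beyond the scatter), in that an amino group carrying an aromatic ring gives way to a tertiary amine built from alkyl carbons only. Because compound 1 already sits at a limit > 8000 nM, and because the comparable exchange gave an at least 3.7-fold higher number from compound 2 to compound 3 (0.56 log units; beyond the scatter), the step that the limit leaves unreadable from compound 1 to compound 4 is expected to run toward weaker inhibition or to stay flat at the limit. Compound 4 is therefore expected to give about 20000 nM in this assay, within 8000 nM to 60000 nM, most likely reported only as a limit.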

Compound 4, half-maximal inhibitory concentration: > 16000 nM
Compound 4 was reported as a limit; the forecaster's own chance of this, stated with the estimate: 75%; the middle value does not contradict the limit.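

In this assay compound 4 gives only a limit, > 16000 nM. Compound 1 also gives only a limit, > 8000 nM, so the exchange of benzylamino for pyrrolidin-1-yl between compound 1 and compound 4 cannot be read as a step. The compounds shown leave open how strongly compound 1, compound 3 and compound 4 actually inhibit, and whether they differ at all.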